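Swapping one ring group: compound 1 to compound 4

The compounds below may be only part of what the source reports. "The series", "measured", "known", "first", "only" and "open" are said of these compounds alone.

Measured so far in an ADME assay on microsomes from liver (Homo sapiens) for metabolic stability; on this read-out lower numbers stand for a shorter-lived compound and higher numbers for a longer-lived compound:
- Compound 1 `CC(C)C(/C=C1\NC(=O)NC1=O)c1ccc(-c2ccc3cccc(F)c3c2)[nH]c1=O` gives > 3 h (a limit, not a number)
- Compound 2 `CCc1cccc2ccc(-c3ccc(C(/C=C4\OC(=O)NC4=O)(CC)CC)c(=O)[nH]3)cc12` gives 0.178 h
- Compound 3 `CCC(CC)C(/C=C1\OC(=O)NC1=O)c1ccc(-c2ccc3cccc(F)c3c2)[nH]c1=O` gives > 3 h (a limit, not a number)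

Compound 1 sits at the limit of > 3 h in this assay, at which 2 of the 3 values shown sit, so its reading is a limit. Compound 4 `CC(C)C(c1ccc(-c2ccc3cccc(F)c3c2)[nH]c1=O)C1SC(=O)NC1=O` has not been measured yet. Its change from compound 1 is this: a group of 7 heavy atoms (3 carbon, 1 nitrogen, 2 oxygen, 1 sulfur; one five-membered non-aromatic ring with 2 hetero atoms) in place of a group of 8 heavy atoms (4 carbon, 2 nitrogen, 2 oxygen; one five-membered non-aromatic ring with 2 hetero atoms), on a saturated chain carbon bound to an aromatic carbon and a saturated chain carbon. The group that enters is 2,4-dioxo-1,3-thiazolidin-5-yl.

For the measured compounds named here, no measured pair shows this swap directly. Compound 3 also gives > 3 h, which is again a limit. Compound 2, however, gives 0.178 h, so short half-lives do occur in this small set. In this assay no change beyond the scatter is expected, and the expected step is a number no higher from compound 1 to compound 4 (the limit leaves the size open). For compound 4 the estimated half-life is 3 h, with an expected range of 1.2 h to 6 h.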

Compound 4, half-life: 1.87 h
Beside the measured number, compound 4's estimate is 1.6-fold (0.21 log units) above it; low and high end bracket the measured number.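

In this assay, for the compounds shown here, the swap to 2,4-dioxo-1,3-thiazolidin-5-yl is the first change at this place that can be read, and it gives an at least 1.6-fold lower number from compound 1 to compound 4 (0.20 log units; that floor lies within the scatter). Compound 1 gives > 3 h, which is a limit, so the true size of the step stays open: the limit of > 3 h in this assay, at which 2 of the 4 values shown sit.

The entering group differs from the leaving one both in its ring atoms, with sulfur among them, and in its double bonds outside aromatic rings, and the compounds shown cannot separate the two. As far as these compounds go, how a carboxylic acid on this saturated chain carbon would read also stays open.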